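Swapping Diethylamino for Trifluoromethyl on a Shared Core

The source may hold more compounds than are shown below. What is called first, only, known or untested is meant among the compounds shown, and "the series" means these compounds.

Compound 1, `CCN(CC)c1cccc2c1[n+]([O-])nc(N)[n+]2[O-]`: 0.83
Compound 2, `Cc1ccc2c(c1)[n+]([O-])nc(N)[n+]2[O-]`: 0.127

Both numbers come from a physicochemical assay on HT-29 cells for lipophilicity; on this read-out higher numbers stand for higher lipophilicity and lower numbers for lower lipophilicity. Compound 1 gives the higher of the two, 0.83, and compound 2 sits lower, at 0.127, a gap beyond the usual scatter. Compound 3 `Nc1n[n+]([O-])c2c(C(F)(F)F)cccc2[n+]1[O-]` has not yet been measured; it differs from compound 1 in one place: trifluoromethyl in place of diethylamino on an aromatic carbon. Among the compounds with values here, no measured pair shows this change, so its size is open. A small downward step, a number 0.33 log units lower from compound 1 to compound 3 (beyond the scatter), is expected in this assay, close to the edge of the scatter. Compound 3 is estimated at 0.5, with a range from 0.1 to 0.9.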

Compound 3, partition coefficient: 0.48
Estimate against measurement, compound 3: 0.02 log units above; low and high end bracket the measured number.
By their numbers in this assay, from the lowest: compound 2; then compound 3; then compound 1.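

In this assay, this aromatic carbon now has its first measured swap: trifluoromethyl in place of diethylamino gives a modest step (a number 0.35 log units lower from compound 1 to compound 3 (beyond the scatter)), beyond the usual scatter. The number therefore responds to what sits at this position on the shared core, although the two groups are similar in heavy-atom count. Nothing available here explains why the number moves.

Within the data shown here, one pair gives only one step, so no trend can be drawn for this position. On these data alone, how a nitrile or a carboxylic acid on the same aromatic carbon would read remains open.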